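The source may report more compounds than this note shows. Statements on the series, on what has been measured and on what is new or still open speak of the compounds shown alone.

Three compounds share one core and differ only on a single aromatic ring. In a functional assay on the whole organism (Abdomen, strain Swiss) for inhibition, with Mus musculus as the target, with stated times of 40 min and 25 min, at a dose of 100 umol/kg by the oral route (on this read-out lower numbers stand for less inhibition and higher numbers for more inhibition at the one dose given (going by the name of the read-out)), compound 1 `COc1cc(/C=N/NC(=O)c2cnccn2)ccc1O` gives 47%. Compound 2 `O=C(N/N=C/c1ccc(O)cc1)c1cnccn1` gives 61.4% in this assay, and compound 3 `O=C(N/N=C/c1ccccc1)c1cnccn1` gives 42.4%. Compound 3 stands lowest of the three numbers, within the scatter of compound 1 but beyond the scatter against compound 2. Compound 4 `O=C(N/N=C/c1ccc(C(F)(F)F)cc1)c1cnccn1` carries trifluoromethyl in place of hydrogen on an aromatic carbon. For the measured compounds named here, two measured steps bear on this change, both on the same ring: a number 14.4 percentage points higher from compound 1 to compound 2 (beyond the scatter) and a number 19 percentage points lower from compound 2 to compound 3 (beyond the scatter), so removing the methoxy raised the read-out while removing the hydroxy lowered it. Going by the values given here, no measured step shows a trifluoromethyl, so no step beyond the scatter is expected. Compound 4 is estimated at 40%, within 22% to 58%. The expected step is a number 2.4 percentage points lower from compound 3 to compound 4 (within the scatter).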

Compound 4, a percentage reported as inhibition, in the whole organism at one dose (the size of the read-out at that dose, not a potency): 54.5%
The estimate for compound 4 lay 14.5 percentage points below the measured number; the range from low to high includes it.
By their numbers in this assay, from the lowest: compounds 3, 1, 4 and 2 (each within the scatter of the next, the first and the last beyond it).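

In this assay, for the compounds shown here, trifluoromethyl in place of hydrogen gives a number 12.1 percentage points higher from compound 3 to compound 4 (beyond the scatter), so hydroxy is no longer the only group on this ring position that lifts the read-out above plain hydrogen. Trifluoromethyl in place of hydroxy gives a number 6.9 percentage points lower from compound 2 to compound 4 (within the scatter), so these two groups cannot be told apart on this read-out. Nothing given here explains why the two groups read alike. On these data alone, whether a single fluorine, an amine or a carboxylic acid at this position would also lift the read-out stays open. So does whether trifluoromethyl would do the same elsewhere on this ring.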